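From cyclobutyloxy to pyrrolidin-1-yl: a clearance question

This account rests on a few compounds, and the source may have more. Where it says the series, first, only, none or still open, it means among the compounds named here.

In a toxicity assay on microsomes from liver (Homo sapiens) for metabolic stability, read by LC-MS, using NADPH, tested at 1 uM (a lower number here means slower removal, a higher number faster removal of the compound), compound 1 `CCOc1ncc(-c2nc(C(F)(F)F)sc2N2CCN(C(=O)Cn3cnc(C(F)(F)F)n3)[C@H](C)C2)cn1` reaches only a limit of the assay, < 10 mL.min-1.g-1. For the measured compounds named here, compound 2 `Cc1nc(C)n(CC(=O)N2CCN(c3sc(C(F)(F)F)nc3-c3cnc(OC4CCC4)nc3)C[C@H]2C)n1` gives the only actual number, 51 mL.min-1.g-1. Compound 3 `Cc1nc(C)n(CC(=O)N2CCN(c3sc(C(F)(F)F)nc3-c3cnc(N4CCCC4)nc3)C[C@H]2C)n1` carries pyrrolidin-1-yl in place of cyclobutyloxy on an aromatic carbon, between two ring nitrogen atoms (pyrrolidin-1-yl in place of cyclobutyloxy on an aromatic carbon). Going by the values given here, no measured pair shows what this exchange does, so no shift beyond the usual scatter is expected in this assay, and the estimated step is small, a 1.2-fold higher number from compound 2 to compound 3 (0.07 log units; within the scatter). For compound 3 the expected value is 60 mL.min-1.g-1, within an estimated range from 25 mL.min-1.g-1 to 130 mL.min-1.g-1.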

Compound 3, intrinsic clearance in microsomes: 338 mL.min-1.g-1
Compound 3: middle estimate off by 5.6-fold (0.75 log units), on the low side; measured number above the stated range.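

In this assay the position between two ring nitrogen atoms proves sensitive to this exchange: pyrrolidin-1-yl in place of cyclobutyloxy gives a 6.6-fold higher number from compound 2 to compound 3 (0.82 log units; beyond the scatter) with the rest of the molecule unchanged. For the compounds shown here, the earlier compounds offered no such pair, so this is the first direct reading of the change, and it rests on one pair alone. No measurement shown here accounts for the rise.

From the compounds shown here alone, whether the rise follows the pyrrolidine ring or any amine at this place stays open; dimethylamino or morpholin-4-yl would separate the two. Whether the same step holds on other amide side chains is also unresolved.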